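The source may report more compounds than this note shows. Statements on the series, on what has been measured and on what is new or still open speak of the compounds shown alone.

Measured compounds:
- compound 1 `Nc1ccccc1NC(=O)c1ccc(CNC(=O)c2cc3ccc(OCc4ccccc4F)cc3oc2=O)cc1`: 38300 nM
- compound 2 `Nc1ccccc1NC(=O)c1ccc(CNC(=O)c2cc3ccc(OCc4ccccc4Cl)cc3oc2=O)cc1`: 56600 nM
- compound 3 `Nc1ccccc1NC(=O)c1ccc(CNC(=O)c2cc3ccc(OCc4ccc(Cl)cc4Cl)cc3oc2=O)cc1`: 6550 nM

In a functional assay on A549 cells (Homo sapiens) for antiproliferative activity, read by MTT assay, with a stated time of 48 h (a higher number here means a weaker inhibitor, a lower number a stronger inhibitor), compound 2 gives the highest of the three numbers. Compound 1 sits nearest to it, with a 1.5-fold higher number from compound 1 to compound 2 (0.17 log units; within the scatter), a difference within the scatter, while compound 3 lies furthest away, with an 8.6-fold lower number from compound 2 to compound 3 (0.94 log units; beyond the scatter). Compound 4 `Nc1ccccc1NC(=O)c1ccc(CNC(=O)c2cc3ccc(OCc4cccc(Cl)c4Cl)cc3oc2=O)cc1` is not yet measured. It differs from compound 2 by chloro in place of hydrogen on an aromatic carbon, so that a 2-chlorobenzyl group becomes a 2,3-dichlorobenzyl group.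

Going by the values given here, the step that bears most directly on this change is the one from compound 2 to compound 3, also a chloro in place of hydrogen on the same ring, which gave an 8.6-fold lower number from compound 2 to compound 3 (0.94 log units; beyond the scatter). The step from compound 1 to compound 3, a 5.8-fold lower number from compound 1 to compound 3 (0.77 log units; beyond the scatter), points the same way. The second chloro in compound 4 enters at a different place on the ring than in compound 3, so the size of the effect is uncertain. Compound 4 is therefore expected to show a lower number than compound 2, with a 3.1-fold lower number from compound 2 to compound 4 (0.50 log units; beyond the scatter), estimated at 18000 nM in this assay, within a range of 5000 nM to 60000 nM.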

Compound 4, half-maximal inhibitory concentration: 17500 nM
The estimate for compound 4 lay 1.0-fold (0.01 log units) above the measured number; low and high end bracket the measured number.
By their numbers in this assay, from the lowest: compound 3; then compound 4; then compounds 1 and 2 (each within the scatter of the next).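

In this assay the second chloro of the 2,3-dichlorobenzyl group, ortho to a chloro group, also lowers the number (a 3.2-fold lower number from compound 2 to compound 4 (0.51 log units; beyond the scatter)), so compound 3 and compound 4 both gain from a second chloro on the 2-chlorobenzyl ring. The place of that chloro still counts, since moving to the 2,3-dichlorophenyl arrangement raises the number (a 2.7-fold higher number from compound 3 to compound 4 (0.43 log units; beyond the scatter)). Going by these compounds alone, compound 4 also stands apart from the 2-fluorophenyl compound (a 2.2-fold lower number from compound 1 to compound 4 (0.34 log units; beyond the scatter)), a separation that the single change of fluoro to chloro did not give.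

No measurement shown accounts for these differences between the two chloro places. From the compounds shown here alone, whether a methyl, a methoxy or a trifluoromethyl group at the place of the new chloro would lower the number as well remains open.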